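Removing the Aryl Methyl: Compound 3 to Compound 4

This account rests on a few compounds, and the source may have more. Where it says the series, first, only, none or still open, it means among the compounds named here.

Measured compounds and values:
Compound 1 `COc1ccc([C@]2(CO)NC[C@@H](O)[C@@H]2O)cc1`: 7.5%
Compound 2 `COc1cccc([C@]2(CO)NC[C@@H](O)[C@@H]2O)c1`: 1.6%
Compound 3 `Cc1ccc([C@]2(CO)NC[C@@H](O)[C@@H]2O)cc1`: 1.6%

In an assay on isolated protein for inhibition of alpha-galactosidase (Coffea arabica), tested at 1000 uM (on this read-out higher numbers stand for more inhibition at the one concentration tested (going by the name of the read-out) and lower numbers for less inhibition), compound 3 gives 1.6%, level with compound 2 at the digits shown, and together these two stand lowest among the three numbers. Compound 1 sits somewhat higher, but the gap to compound 3 lies within the scatter, so no order among the three can be claimed.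

Compound 4 `OC[C@@]1(c2ccccc2)NC[C@@H](O)[C@@H]1O` has not been measured in this assay. It differs from compound 3 by hydrogen in place of methyl on an aromatic carbon.

Going by the values given here, only one measured step bears on this change: a number 5.9 percentage points lower from compound 1 to compound 3 (within the scatter), a swap of one aryl substituent for another at the same position, which stayed within the scatter. Among the compounds with values here, no measured step removes the substituent altogether, so the expectation rests on that single small step and on the fact that all three measured compounds cluster at low inhibition. Compound 4 is therefore expected to show no step beyond the scatter, a number 1.4 percentage points higher from compound 3 to compound 4 (within the scatter). For compound 4 the estimate is 3%, with a range from 0% to 12%.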

Compound 4, a percentage reported as inhibition, at one concentration (the size of the read-out at that concentration, not a potency): 9.9%
Estimate against measurement, compound 4: 6.9 percentage points below; the range from low to high includes it.
By their numbers in this assay, from the lowest: compounds 2, 3, 1 and 4 (each within the scatter of the next).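

Going by these compounds alone, compound 4 gives the first reading in this assay with only hydrogen on this aromatic carbon, and taking the methyl away gives a number 8.3 percentage points higher from compound 3 to compound 4 (within the scatter). Putting hydrogen in place of methoxy gives a number 8.3 percentage points higher from compound 2 to compound 4 (within the scatter) and a number 2.4 percentage points higher from compound 1 to compound 4 (within the scatter). The earlier compounds shown here showed only one substituent swapped for another, whereas these steps show that removing the substituent altogether, whether methyl or methoxy, also stays within the scatter, and no evidence beyond these percentages bears on the result.

The compounds shown leave open whether a different kind of group on the aromatic ring, such as an amine, a carboxylic acid or a longer alkyl chain, would stand apart from compound 4 by more than the scatter. They also leave open whether any real order exists among these four compounds, as each reading comes from a single high concentration and every listed step between them lies within the scatter.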